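The compounds below may be only part of what the source reports. "The series", "measured", "known", "first", "only" and "open" are said of these compounds alone.

Measured compounds:
compound 1 `CN(C(=O)NC(=O)c1c(F)cccc1F)c1nc(C(F)(F)F)c(C(=O)N/N=C/c2cccc(C(F)(F)F)c2)s1` with 21.6 ug/mL
compound 2 `CN(C(=O)NC(=O)c1ccc(F)c(F)c1)c1nc(C(F)(F)F)c(C(=O)N/N=C/c2cccc(C(F)(F)F)c2)s1` with 4.21 ug/mL
compound 3 `CN(C(=O)NC(=O)c1c(F)cccc1F)c1nc(C(F)(F)F)c(C(=O)N/N=C/c2cc(C(F)(F)F)cc(C(F)(F)F)c2)s1` with 5.62 ug/mL

All three were tested in a functional assay on HeLa cells (Homo sapiens) for inhibition, read by MTT assay, with a stated time of 72 h; a lower number here means a stronger inhibitor, a higher number a weaker inhibitor. Among them compound 1 gives the highest number; the nearest is compound 3, reached by a 3.8-fold lower number from compound 1 to compound 3 (0.58 log units; beyond the scatter), and the furthest is compound 2, reached by a 5.1-fold lower number from compound 1 to compound 2 (0.71 log units; beyond the scatter). Both steps leave compound 1 as the weakest inhibitor of the three.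

Compound 4 `CN(C(=O)NC(=O)c1c(F)cccc1F)c1nc(C(F)(F)F)c(C(=O)N/N=C/c2ccccc2C(F)(F)F)s1` has not yet been measured. It differs from compound 1 in one place: 2-(trifluoromethyl)phenyl in place of 3-(trifluoromethyl)phenyl on a carbon with a double bond to nitrogen. The two molecules share every atom; only the position of the trifluoromethyl on the ring attached to the hydrazone carbon changes.

Within the data shown here, no measured step moves a trifluoromethyl around that ring. The step from compound 1 to compound 3 touches the same ring but adds a second trifluoromethyl rather than shifting one, and the step from compound 1 to compound 2 changes the other aryl group entirely. Neither therefore speaks directly to this change, and the expectation for compound 4 in this assay is a step within the usual scatter, in no firm direction, a 1.1-fold lower number from compound 1 to compound 4 (0.03 log units; within the scatter). Compound 4 is thus estimated at 20 ug/mL, with a range from 7 ug/mL to 60 ug/mL.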

Compound 4, half-maximal inhibitory concentration: 19.6 ug/mL
For compound 4 the middle estimate is 1.0-fold (0.01 log units) above the measured one; the range from low to high includes it.
By their numbers in this assay, from the lowest: compounds 2 and 3 (each within the scatter of the next); then compounds 4 and 1 (each within the scatter of the next).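

In this assay, among these compounds, the step from 3-(trifluoromethyl)phenyl to 2-(trifluoromethyl)phenyl on a carbon with a double bond to nitrogen gives a 1.1-fold lower number from compound 1 to compound 4 (0.04 log units; within the scatter) and so leaves the number unresolved from that of the parent, a point the earlier compounds could not settle, since none of them moved the trifluoromethyl around this ring. Among the compounds shown here, the one other change on this ring, the added second trifluoromethyl, gives a 3.8-fold lower number from compound 1 to compound 3 (0.58 log units; beyond the scatter) and lies beyond the scatter, so for these compounds adding a trifluoromethyl registers in this assay while shifting the existing one between these two placements does not. No measurement here offers any explanation for the two placements reading alike.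

On these data alone, it remains open whether the same shift would also leave the number in place when the 3,4-difluorophenyl group of compound 2 stands in for the 2,6-difluorophenyl group. The compounds shown also leave open how this ring would respond if the trifluoromethyl were replaced by another group, such as a methoxy, a nitrile, an amine or a carboxylic acid.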